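A few compounds are considered here, and "the series" means these few. Any claim that something is new, unique, unknown or untested is made for them only; others in the source may bear on it.

Measured in an ADME assay on Vero cells (Chlorocebus sabaeus) for cytotoxicity, read by MTT assay, with a stated time of 72 h; a higher number here means a weaker inhibitor, a lower number a stronger inhibitor:
- Compound 1 `O=C(O)c1cn2c(n1)CN(c1nc3c(cc1[N+](=O)[O-])c(=O)c(C(=O)O)cn3C1CC1)CC2`: 142000 nM
- Compound 2 `CC(C)(C)n1cc(C(=O)O)c(=O)c2cc([N+](=O)[O-])c(N3CCC(n4c(=O)[nH]c5cc(Cl)ccc54)CC3)nc21`: 57700 nM

Compound 1 stands highest of the two at 142000 nM, and the gap down to compound 2 lies beyond the usual scatter. Compound 3 `CC(C)(C)n1cc(C(=O)O)c(=O)c2cc([N+](=O)[O-])c(N3CCn4cc(C(=O)O)nc4C3)nc21` keeps the rest of compound 1 but has tert-butyl in place of cyclopropyl on an aromatic nitrogen. Going by the values given here, no measured pair differs in one place only, so there is no direct precedent for this change. Compound 2 also carries tert-butyl and gives 57700 nM, which points to a small drop at most in this assay. The expected step is a 1.4-fold lower number from compound 1 to compound 3 (0.15 log units; within the scatter), probably within the scatter. The estimated value for compound 3 is 100000 nM, with an expected range of 45000 nM to 220000 nM.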

Compound 3, half-maximal inhibitory concentration: > 136000 nM
Compound 3 gave a limit, no number (the forecaster's own chance of this, stated with the estimate: 20%); middle value at least 1.3-fold (0.13 log units) from the limit.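

Going by these compounds alone, compound 3 gives only a limit, not a number, so no step from compound 1 to compound 3 can be read, because the result sets no measured value: the limit of > 136000 nM in this assay, at which 1 of the 3 values shown sits.
From the compounds shown here alone, whether tert-butyl in place of cyclopropyl on an aromatic nitrogen changes the result in this assay stays open.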